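Dichlorobenzyl in place of fluorobenzyl on a pyrazole carboxamide

This account rests on a few compounds, and the source may have more. Where it says the series, first, only, none or still open, it means among the compounds named here.

Measured compounds:
compound 1, `O=C(NOCc1ccccc1F)c1cn(-c2ccccc2)nc1-c1ccccc1`, 5940 nM
compound 2, `Cc1ccc(-c2nn(-c3ccccc3)cc2C(=O)NOCc2ccccc2)cc1`, 1140 nM
compound 3, `Cc1ccc(-c2nn(-c3ccccc3)cc2C(=O)NOCc2ccccc2F)cc1`, 260 nM

These three compounds were tested in a functional assay on A549 cells (Homo sapiens) for antiproliferative activity, read by MTT assay, with a stated time of 48 h, in the presence of a further agent that is not named here; on this read-out lower numbers stand for stronger inhibition of growth and higher numbers for weaker inhibition of growth. On these numbers compound 3 stands lowest; compound 2 is nearest to it, and compound 1 is furthest. The step of a 4.4-fold lower number from compound 2 to compound 3 (0.64 log units; beyond the scatter) came with a fluoro in place of hydrogen on an aromatic carbon, and the step of a 23-fold lower number from compound 1 to compound 3 (1.36 log units; beyond the scatter) with a methyl in place of hydrogen on an aromatic carbon.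

Compound 4, `Cc1ccc(-c2nn(-c3ccccc3)cc2C(=O)NOCc2ccc(Cl)cc2Cl)cc1`, differs from compound 3 by 2,4-dichlorophenyl in place of 2-fluorophenyl on a saturated chain carbon bound to an oxygen. The step from compound 2 to compound 3 bears on it, since it also changes the same ring, and it was modest in size; the step from compound 1 to compound 3 touches a different part of the molecule. Going by the values given here, no measured pair shows what two chlorines do on this ring, so the direction is open. Compound 4 is therefore expected to stay near compound 3, with the step estimated as a 1.5-fold higher number from compound 3 to compound 4 (0.19 log units; within the scatter). Compound 4 is estimated at 400 nM, within a range from 100 nM to 1600 nM.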

Compound 4, concentration for 50% growth inhibition: 1080 nM
Compound 4: the middle estimate sits 2.7-fold (0.43 log units) below what was measured, within the range that was stated.
By their numbers in this assay, from the lowest: compound 3; then compounds 4 and 2 (each within the scatter of the next); then compound 1.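

In this assay, 2,4-dichlorophenyl in place of 2-fluorophenyl on a saturated chain carbon bound to an oxygen gives a 4.2-fold higher number from compound 3 to compound 4 (0.62 log units; beyond the scatter), so the gain seen with 2-fluorophenyl does not extend to every halogen-bearing ring at this place. Set against plain phenyl, the same group gives a 1.1-fold lower number from compound 2 to compound 4 (0.02 log units; within the scatter), which means that these two compounds cannot be told apart here and that, among the three rings compared, only 2-fluorophenyl stands apart. Nothing measured on these compounds accounts for this difference.

The compounds shown leave open whether the lost gain comes with the second chlorine or with chlorine itself, which a ring carrying a single chlorine could begin to separate. On these data alone, how a methoxy group or an amine on this ring would behave also remains open.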